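A few compounds are considered here, and "the series" means these few. Any claim that something is new, unique, unknown or untested is made for them only; others in the source may bear on it.

Measured so far in a functional assay on HT-29 cells (Homo sapiens) for inhibition, read by WST assay, with a stated time of 48 h; on this read-out lower numbers stand for stronger inhibition and higher numbers for weaker inhibition:
- compound 1 `O=C(CSc1nc2ccccc2[nH]1)c1ccc(O)cc1`: 19200 nM
- compound 2 `Cc1ccc(C(=O)CSc2nc3ccccc3[nH]2)cc1`: 34500 nM

Compound 2 gives the highest of the two numbers, and its nearest neighbour is compound 1, the step being a 1.8-fold higher number from compound 1 to compound 2 (0.25 log units; within the scatter) — so the two compounds cannot be told apart. Within the data shown here, that single step, methyl in place of hydroxy on the aromatic carbon, is the only measured change.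

Compound 3 `O=C(CSc1nc2ccccc2[nH]1)c1ccc(F)cc1` is not yet measured. Relative to compound 2 the change is fluoro in place of methyl on an aromatic carbon. Among the measured compounds shown here, the one measured step, from hydroxy to methyl, stayed within the scatter, and no measured pair shows what fluoro does at this position. With nothing in the data pointing either way, no step beyond the scatter is expected from compound 2 to compound 3, the expected step being a 1.2-fold lower number from compound 2 to compound 3 (0.06 log units; within the scatter). Compound 3 is therefore estimated at 30000 nM in this assay, with a range from 12000 nM to 75000 nM.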

Compound 3, half-maximal inhibitory concentration: 78700 nM
Beside the measured number, compound 3's estimate is 2.6-fold (0.42 log units) below it; measured number above the stated range.
By their numbers in this assay, from the lowest: compounds 1 and 2 (each within the scatter of the next); then compound 3.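

In this assay, the group on the aromatic carbon para to a large group now shifts the number beyond the scatter, with a 2.3-fold higher number from compound 2 to compound 3 (0.36 log units; beyond the scatter) for fluoro in place of methyl and a 4.1-fold higher number from compound 1 to compound 3 (0.61 log units; beyond the scatter) for fluoro in place of hydroxy. Both steps are modest, but they show that this position is not indifferent to its substituent, which the step between hydroxy and methyl alone could not show. Among these three groups, fluoro is the one that separates from the other two, and nothing available accounts for that difference.

The compounds shown leave open whether the higher number is particular to fluoro or is shared by chloro or bromo at the same place. They also leave open how an amine, a methoxy group or a carboxylic acid there would compare with hydroxy and methyl.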